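Halogenated series: working notes toward compound 3

The compounds below may be only part of what the source reports. "The series", "measured", "known", "first", "only" and "open" are said of these compounds alone.

Measured so far in a functional assay on NCI-H292 cells (Homo sapiens) for cytotoxicity, read by MTT assay, with a stated time of 72 h, tested at 1.25 ug/mL; a higher number here means more inhibition of growth at the concentration tested, a lower number less inhibition of growth:
compound 1 `O=C1NC(=S)/C(=C/c2ccccc2Cl)S1` gives 10.6%;
compound 2 `O=C1NC(=S)/C(=C/c2ccccc2F)S1` gives 4.29%.

Compound 1 is the point of reference here; the step of a number 6.3 percentage points lower from compound 1 to compound 2 (within the scatter) lies within the scatter, so the two measured compounds cannot be told apart in this assay. Compound 3 `O=C1NC(=S)/C(=C/c2c(Cl)cccc2Cl)S1` differs from compound 1 by chloro in place of hydrogen on an aromatic carbon. Within the data shown here, the only measured step, a fluoro for chloro swap, bears on this change merely as a sign that a halogen exchange left this assay unmoved; no measured step adds a second chloro. No step beyond the scatter is therefore expected. The estimate for compound 3 is 14%, range 2% to 30%, an expected step of a number 3.4 percentage points higher from compound 1 to compound 3 (within the scatter).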

Compound 3, percent growth inhibition at one concentration: 4.36%
Estimate against measurement, compound 3: 9.6 percentage points above, and the stated range covers the measured number.
By their numbers in this assay, from the lowest: compounds 2, 3 and 1 (each within the scatter of the next).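

In this assay, adding a chloro on an aromatic carbon, ortho to a group of 8 heavy atoms and meta to a chloro group, gives a number 6.2 percentage points lower from compound 1 to compound 3 (within the scatter) and does not separate the two compounds. Among these compounds, this is the first step that adds a group at a hydrogen-bearing ring carbon rather than exchanging one halogen for another, and it too stays inside the scatter.

On these data alone, whether an amine or a carboxylic acid at this position would give a step beyond the scatter remains open. No available evidence bears on this result.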